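The compounds below may be only part of what the source reports. "The series", "measured", "known", "first", "only" and "open" are said of these compounds alone.

Measured so far in a functional assay on the whole organism (blood, strain albino) with Mus musculus as the target, with stated times of 6 days and 4 h, at a dose of 0.4 mmol/kg by the oral route; a higher number here means more inhibition at the dose given (going by the name of the read-out), a lower number less inhibition:

compound 1, `C=CCNC(=S)NS(=O)(=O)c1ccc(-n2nc(C(=O)O)cc2C)cc1`: -6%
compound 2, `CCNC(=O)NS(=O)(=O)c1ccc(-n2nc(C(=O)O)cc2C)cc1`: 0%
compound 3, `Cc1cc(C(=O)O)nn1-c1ccc(S(=O)(=O)NC(=S)Nc2ccccc2)cc1`: 0%

Compound 3 stands level with compound 2 at the digits given, the two of them together the highest of the three numbers; the nearest of the others is compound 2, with no change at the digits printed from compound 2 to compound 3 (within the scatter), and the furthest is compound 1, with a number 6 percentage points higher from compound 1 to compound 3 (within the scatter). All three numbers sit within the scatter of one another, so no ordering among them can be read.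

Compound 4 is `CCCCNC(=O)NS(=O)(=O)c1ccc(-n2nc(C(=O)O)cc2C)cc1`. Against compound 3 the change is a group of 7 heavy atoms (5 carbon, 1 nitrogen, 1 oxygen; no ring) in place of a group of 9 heavy atoms (7 carbon, 1 nitrogen, 1 sulfur; one six-membered aromatic ring of carbon only), on a sulfonamide nitrogen.

For the measured compounds named here, two measured steps bear on this position on the sulfonamide nitrogen. The step of no change at the digits printed from compound 2 to compound 3 (within the scatter) exchanged one group there for another and left the number unchanged at the digits given; the step of a number 6 percentage points higher from compound 1 to compound 2 (within the scatter) did the same and stayed within the scatter. Neither step suggests that this position moves the read-out of this assay, and nothing measured on the shared core does otherwise. A step of no change at the digits printed from compound 3 to compound 4 (within the scatter) is therefore expected, that is none beyond the scatter.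

For compound 4 the expected value is 0%, with a range from -10% to 10%.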

Compound 4, a percentage reported as inhibition, in the whole organism at one dose (the size of the read-out at that dose, not a potency): 2%
The estimate for compound 4 lay 2 percentage points below the measured number; the measured number falls inside the stated range.
By their numbers in this assay, from the lowest: compounds 1, 2, 3 and 4 (each within the scatter of the next).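

In this assay, for the compounds shown here, butylcarbamoyl on the sulfonamide nitrogen gives the first comparison of chain size on this position, and the read-out does not respond: ethyl in place of hydrogen on the saturated chain carbon gives a number 2 percentage points higher from compound 2 to compound 4 (within the scatter) as its step. Giving up the aromatic ring of compound 3 for this open chain also has little effect, with a number 2 percentage points higher from compound 3 to compound 4 (within the scatter) as the step. Exchanging the sulfur-bearing allyl group of compound 1 for butylcarbamoyl gives a number 8 percentage points higher from compound 1 to compound 4 (within the scatter) as the step, so no group at this position yet stands apart from the others.

From the compounds shown here alone, whether a longer chain such as octyl, a cyclohexyl group on this nitrogen, or a methyl ester in place of the carboxylic acid on the shared core would separate from these numbers remains open. No supporting data bear on this flat result.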